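Azabicyclic pyridines: 2-methoxyphenyl to methyl on the oxygen

This account rests on a few compounds, and the source may have more. Where it says the series, first, only, none or still open, it means among the compounds named here.

Measured so far:
compound 1 `COc1ccccc1Oc1cncc(C2=CC3CNCC(C2)C3)c1`: 1 nM
compound 2 `COc1cc(C2=CC3CC(C2)CN(C)C3)cnc1Cl`: 4.4 nM
compound 3 `Clc1ccncc1C1=CC2CNCC(C1)C2`: 3 nM

In an in vitro assay on SH-EP1 cells for displacement of a labelled ligand from Neuronal acetylcholine receptor; alpha4/beta2 (Homo sapiens) (on this read-out higher numbers stand for weaker inhibition and lower numbers for stronger inhibition), compound 1 gives 1 nM, the lowest number of the three. Compound 3 gives 3 nM and compound 2 gives 4.4 nM, both beyond the scatter from compound 1, so compound 1 is the strongest inhibitor measured here. Compound 4 `COc1cncc(C2=CC3CNCC(C2)C3)c1` is not yet measured. It differs from compound 1 in one place: methyl in place of 2-methoxyphenyl on an oxygen on an aromatic ring. For the measured compounds named here, no measured pair shows this change directly. Compound 3, which has no 2-methoxyphenyl, still gives 3 nM, and compound 2 gives 4.4 nM. A step of a 5.0-fold higher number from compound 1 to compound 4 (0.70 log units; beyond the scatter) is therefore expected, toward weaker inhibition but modest. Compound 4 is estimated at 5 nM, within 1.5 nM to 20 nM.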

Compound 4, inhibition constant: 0.3 nM
Estimate against measurement, compound 4: 17-fold (1.22 log units) above; measured number below the stated range.
By their numbers in this assay, from the lowest: compound 4; then compound 1; then compounds 3 and 2 (each within the scatter of the next).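

Methyl in place of 2-methoxyphenyl on an oxygen on an aromatic ring gives a 3.3-fold lower number from compound 1 to compound 4 (0.52 log units; beyond the scatter) in this assay, so the step runs toward stronger inhibition with the smaller group. At this position, the six-membered aromatic ring of 2-methoxyphenyl is therefore not required for inhibition at this level. Nothing among the data shown accounts for the gain.

The compounds shown leave open whether an ethyl group or a longer chain on the same oxygen would hold this gain. From the compounds shown here alone, how a free hydroxyl group would compare in that place also remains open.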